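This account rests on a few compounds, and the source may have more. Where it says the series, first, only, none or still open, it means among the compounds named here.

Three compounds have been measured in a functional assay on L929 cells (Mus musculus) for inhibition, read by MTT assay, with a stated time of 5 days; a lower number here means a stronger inhibitor, a higher number a weaker inhibitor:

Compound 1 `Cc1ccc(N(Cc2ccccc2)Cc2ccccc2)cc1` gives 11 ug/mL.
Compound 2 `Cc1ccc(N(Cc2ccccc2)CC(C)C)cc1` gives 5 ug/mL.
Compound 3 `COc1ccc(N(Cc2ccccc2OC)CC(C)C)cc1` gives 15 ug/mL.

Compound 1 and compound 2 share a core and differ in one place: phenyl in place of isopropyl on a saturated chain carbon bound to a nitrogen on an aromatic ring. That change produced a 2.2-fold higher number from compound 2 to compound 1 (0.34 log units; beyond the scatter). Compound 3 has a different core; the difference between the two cores is not broken down here. Compound 3 and compound 1 give numbers within the usual scatter of each other, while compound 2 gives a number beyond the scatter from compound 3.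

Compound 4 `COc1ccc(N(Cc2ccccc2)Cc2ccccc2OC)cc1` has not yet been measured. It relates to compound 3 exactly as compound 1 relates to compound 2: phenyl in place of isopropyl on a saturated chain carbon bound to a nitrogen on an aromatic ring. The place of the change reads the same in both pairs, so this is the same change made on a second core. If it behaves as it did in the first pair, the step in this assay from compound 3 to compound 4 is expected to be a 2.0-fold higher number from compound 3 to compound 4 (0.30 log units; within the scatter), resting on the single earlier example of the same change, a 2.2-fold higher number from compound 2 to compound 1 (0.34 log units; beyond the scatter), which gives only one point of reference. On that basis compound 4 is estimated at 30 ug/mL, with a range from 12 ug/mL to 75 ug/mL.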

Compound 4, half-maximal inhibitory concentration: > 40 ug/mL
Compound 4 ended at the assay's limit (the forecaster's own chance of this, stated with the estimate: 10%); middle value at least 1.3-fold (0.12 log units) away from the limit.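

In this assay compound 4 gives > 40 ug/mL as a limit of the assay, not as a number. With phenyl in place of isopropyl, the step on the second core is an at least 2.6-fold higher number from compound 3 to compound 4 (0.42 log units; beyond the scatter) and so runs in the same direction as on the first core, with the number rising beyond the scatter on both. This shows that the direction carried over in these two pairs, but it does not fix the size of the second step or show whether the two steps are the same size: the same change on two cores in this assay, a 2.2-fold higher number (0.34 log units; beyond the scatter) from compound 2 to compound 1 and an at least 2.6-fold higher number (0.42 log units; beyond the scatter) from compound 3 to compound 4; the limit leaves it open whether they differ

Both pairs make the same change, so the compounds shown leave open how another group at this place, such as an amine or a longer chain, would behave. On these data alone, they also leave open whether the step would keep its direction on a core carrying a carboxylic acid, and the true size of the second step stays unknown while compound 4 rests at a limit.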